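Swapping one sulfonamide group on the most potent compound

This account rests on a few compounds, and the source may have more. Where it says the series, first, only, none or still open, it means among the compounds named here.

compound 1 `O=C(/C=C/c1cccnc1)NCCCCc1ccc(S(=O)(=O)Nc2ccccc2)cc1`: 24.2 nM
compound 2 `O=C(/C=C/c1cccnc1)NCCCCCc1cccc(S(=O)(=O)Nc2ccccc2)c1`: 41.1 nM
compound 3 `Cc1ccccc1NS(=O)(=O)c1cccc(CCCCCCNC(=O)/C=C/c2cccnc2)c1`: 0.525 nM

All three numbers come from a functional assay on Huh-7 cells (Homo sapiens) for inhibition, read by CCK-8 assay, with a stated time of 72 h (on this read-out higher numbers stand for weaker inhibition and lower numbers for stronger inhibition), and from no other test. For the measured compounds named here, compound 3 holds the lowest number of the three, beyond the usual scatter from both others, which makes it the most potent compound so far. It differs from compound 1 and from compound 2 in more than one place, so these values cannot credit its standing to any single feature.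

Compound 4 `O=C(/C=C/c1cccnc1)NCCCCCCc1cccc(S(=O)(=O)Nc2ccc(Cl)cc2)c1` has not yet been measured. It keeps everything in compound 3 except one group, with 4-chlorophenyl in place of 2-methylphenyl on a sulfonamide nitrogen. Going by the values given here, no measured pair isolates this change, so any forecast is loose. The main reason to expect a higher number is that compound 3 at 0.525 nM stands far under compound 1 at 24.2 nM and compound 2 at 41.1 nM, so a new compound is more likely to land above it than under it. In this assay a moderate expected step towards weaker inhibition is a 3.8-fold higher number from compound 3 to compound 4 (0.58 log units; beyond the scatter), although no change beyond the scatter remains possible. Compound 4 is expected at 2 nM, with an estimated range from 0.4 nM to 10 nM.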

Compound 4, half-maximal inhibitory concentration: 24.1 nM
Estimate against measurement, compound 4: 12-fold (1.08 log units) below; measured number above the stated range.
By their numbers in this assay, from the lowest: compound 3; then compounds 4, 1 and 2 (each within the scatter of the next).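

In this assay, for the compounds shown here, the replacement of 2-methylphenyl by 4-chlorophenyl on the sulfonamide nitrogen gives a 46-fold higher number from compound 3 to compound 4 (1.66 log units; beyond the scatter) and this is the first reading that isolates a single group. Both groups have the same heavy-atom count and one six-membered aromatic ring of carbon only, with no hydrogen-bond donors or acceptors, so these counts do not separate them; even so, the number changes strongly, which shows that this position is sensitive and that the standing of compound 3 depends on the group held there. Nothing measured here explains the size of this step.

The swap alters both the atom on the aromatic ring and the place named in the group, so the compounds shown cannot separate these two changes, whereas 2-chlorophenyl or 4-methylphenyl on the same nitrogen would help to do so. On these data alone, it also remains open how much of the standing of compound 3 comes from its methyl group, a question that plain phenyl on this nitrogen, with everything else in compound 3 kept, could address.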